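Swapping the hydroxycyclohexyl amide for a small methyl amide

A few compounds are considered here, and "the series" means these few. Any claim that something is new, unique, unknown or untested is made for them only; others in the source may bear on it.

Of the compounds shown here, three sharing one core have been measured in an ADME assay for permeability; a lower number here means that the compound crosses the layer more slowly, a higher number that the compound crosses the layer faster. Compound 1 `CNC(=O)c1cc(C(=O)N[C@H]2CC[C@H](O)CC2)n([C@@H](C)c2cccc(Cl)c2)n1` gives 235 nm/s, compound 2 `CNC(=O)c1cc(C(=O)N[C@H]2CC[C@H](O)CC2)n([C@@H](C)c2ccccc2)n1` gives 80 nm/s, and compound 3 `CNC(=O)c1cc(C(=O)N[C@H]2CC[C@H](O)CC2)n([C@@H](C)c2cccc(C)c2)n1` gives 110 nm/s. Compound 2 sits at the low end of these three numbers: the step of a 2.9-fold lower number from compound 1 to compound 2 (0.47 log units; beyond the scatter) is beyond the scatter, whereas the step of a 1.4-fold higher number from compound 2 to compound 3 (0.14 log units; within the scatter) is within it, so compound 2 and compound 3 cannot be told apart. The step of a 2.1-fold lower number from compound 1 to compound 3 (0.33 log units; beyond the scatter) is also modest but beyond the scatter.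

Compound 4 `CNC(=O)c1cc(C(=O)NC)n([C@@H](C)c2ccccc2)n1` is not yet measured. It differs from compound 2 in one place: methyl in place of 4-hydroxycyclohexyl on an amide-type nitrogen. Among the compounds with values here, every measured step so far concerns a substituent on the aromatic ring, and none touches the amide-type nitrogen, so no measured step bears directly on this change. The change removes a group carrying one hydrogen-bond donor and one hydrogen-bond acceptor and replaces it with a single carbon. On that basis, and with considerable uncertainty, compound 4 is expected to give a somewhat higher number than compound 2, a step of about a 2.0-fold higher number from compound 2 to compound 4 (0.30 log units; within the scatter) in this assay. The estimate for compound 4 in this assay is therefore 160 nm/s, with a range from 70 nm/s to 360 nm/s.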

Compound 4, apparent permeability in the ADME assay: 280 nm/s
For compound 4 the middle estimate is 1.8-fold (0.24 log units) below the measured one; measured number inside the range.
By their numbers in the ADME assay, from the lowest: compounds 2 and 3 (each within the scatter of the next); then compounds 1 and 4 (each within the scatter of the next).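

Within the data shown here, in the ADME assay the change from 4-hydroxycyclohexyl to methyl on an amide-type nitrogen gives a 3.5-fold higher number from compound 2 to compound 4 (0.54 log units; beyond the scatter) and is the first step measured at this place, so the number responds here as well as to substituents on the aromatic ring. In a physicochemical assay for solubility (on this read-out lower numbers stand for lower solubility and higher numbers for higher solubility), compound 2 gives >= 180 ug/mL as a limit of the assay, not a number. In the physicochemical assay compound 4 gives >= 88 ug/mL as a limit of the assay, not a number.

With only these two limits, the step between compound 2 and compound 4 in the physicochemical assay cannot be read, and nothing measured here gives a cause for the step in the ADME assay. Also open, on these data alone, is which part of the 4-hydroxycyclohexyl matters, as the ring and its hydroxyl leave together; a plain cyclohexyl, an ethyl or a longer carbon chain on the same nitrogen would help to separate the two.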